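This account rests on a few compounds, and the source may have more. Where it says the series, first, only, none or still open, it means among the compounds named here.

The series is followed in a functional assay on CWR22R cells (Homo sapiens) for antiproliferative activity, read by CCK-8 assay, with a stated time of 6 days; on this read-out higher numbers stand for weaker inhibition and lower numbers for stronger inhibition. Compound 1 `CCN(c1ccc(C#N)c(Cl)c1)c1cc(-c2cncnc2)ccc1C` is recorded there only as a limit: in this assay compound 1 gives > 30000 nM, a limit of the assay rather than a number. Among the three entries shown, that limit is the single value with any figure attached, (the limit of > 30000 nM in this assay, at which 1 of the 3 values shown sits), so compound 1 stands at the edge of what the assay resolves. Compound 2 `N#Cc1ccc(N2CCc3cc(-c4cncnc4)ccc3C2)cc1C(F)(F)F` carries no result in this assay, compound 2 giving "not determined" (no result reported). Compound 3 `Cc1noc(C)c1-c1cccc2c1CCCN2c1ccc(C#N)c(C(F)(F)F)c1` likewise has no result, compound 3 giving "not determined" (no result reported). Compound 4 `CCN(c1ccc(C#N)c(Cl)c1)c1cc(-n2cnc3ccccc32)ccc1C` is the next compound to be measured. It differs from compound 1 in one place (1H-benzimidazol-1-yl in place of pyrimidin-5-yl on an aromatic carbon). Among the measured compounds shown here, no step between two measured compounds exists to calibrate this change, and a limit gives no anchor for a direction. The expected step from compound 1 to compound 4 is therefore judged cautiously as an at least 2.0-fold lower number from compound 1 to compound 4 (0.30 log units; that floor lies within the scatter), with a real chance that compound 4 also returns only a limit. Compound 4 is expected to give an estimated 15000 nM in this assay, within a range from 3000 nM to 60000 nM.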

Compound 4, half-maximal inhibitory concentration: 3040 nM
Compound 4: middle estimate off by 4.9-fold (0.69 log units), on the high side; measured number inside the range.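

Exchanging pyrimidin-5-yl for 1H-benzimidazol-1-yl on the aromatic carbon para to a methyl group gives, in this assay, an at least 9.8-fold lower number from compound 1 to compound 4 (0.99 log units; beyond the scatter), so this position is shown for the first time to bear on the read-out. The two groups count the same 0 hydrogen-bond donors and 2 hydrogen-bond acceptors, so the change lies not in those counts but in the ring make-up, with 9 heavy atoms entering where 6 leave. The step is only a lower bound because compound 1 is recorded as a limit: the limit of > 30000 nM in this assay, at which 1 of the 4 values shown sits.

With a single step, the compounds shown cannot separate the effect of the five-membered aromatic ring from that of the added carbon-only ring. Going by these compounds, a plain 1H-imidazol-1-yl group at the same place would bear on that question, and how far the trend extends remains open.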